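Chloro substitution on the aryl ring: toxicity in RD cells

A few compounds are considered here, and "the series" means these few. Any claim that something is new, unique, unknown or untested is made for them only; others in the source may bear on it.

Compound 1 `CCCC[C@H](CCn1cncn1)c1ccccc1` and compound 2 `CCCC[C@H](CCn1cncn1)c1ccc(Cl)cc1` share a core; compound 2 differs by chloro in place of hydrogen on an aromatic carbon. In an ADME assay on RD cells (Homo sapiens) for cytotoxicity, read by MTT assay, with a stated time of 3 days (on this read-out higher numbers stand for lower toxicity in this test and lower numbers for higher toxicity in this test), compound 1 gives 48.3 ug/mL and compound 2 gives 20.3 ug/mL, a step of a 2.4-fold lower number from compound 1 to compound 2 (0.38 log units; beyond the scatter).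

Compound 3 `c1ccc(C[C@H](CCn2cncn2)c2ccccc2)cc1` differs from compound 1 by phenyl in place of propyl on a saturated chain carbon, two bonds along the chain from an aromatic carbon; in this assay compound 3 gives 55.4 ug/mL, a step of a 1.1-fold higher number from compound 1 to compound 3 (0.06 log units; within the scatter). Compound 3 and compound 1 thus cannot be ordered, and compound 2 alone stands apart from the other two.

Compound 4 `Clc1ccc([C@@H](CCn2cncn2)Cc2ccccc2)cc1` is not yet measured. It differs from compound 3 by chloro in place of hydrogen on an aromatic carbon, the same change as from compound 1 to compound 2, at the same place.

In this assay compound 4 is expected to show a step of a 2.3-fold lower number from compound 3 to compound 4 (0.36 log units; beyond the scatter), close to the earlier one, because compound 2 reached 20.3 ug/mL from compound 1 by the same change. The estimate for compound 4 is 24 ug/mL, expected to fall between 12 ug/mL and 48 ug/mL. The pattern rests on a single measured pair, so it is tentative.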

Compound 4, half-maximal cytotoxic concentration: 24.4 ug/mL
Compound 4: middle estimate off by 1.0-fold (0.01 log units), on the low side; the range from low to high includes it.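

In this assay, chloro in place of hydrogen on the aromatic carbon gives a 2.3-fold lower number from compound 3 to compound 4 (0.36 log units; beyond the scatter), and this step carries over from the propyl-bearing core to the phenyl-bearing core with no readable difference in size: the same change on two cores in this assay, a 2.4-fold lower number (0.38 log units; beyond the scatter) from compound 1 to compound 2 and a 2.3-fold lower number (0.36 log units; beyond the scatter) from compound 3 to compound 4, 1.0-fold (0.02 log units) apart, within the scatter of two such steps

Phenyl in place of propyl on the saturated chain carbon gives a 1.2-fold higher number from compound 2 to compound 4 (0.08 log units; within the scatter), so this change also reads the same with or without the chloro: the same change on two cores in this assay, a 1.1-fold higher number (0.06 log units; within the scatter) from compound 1 to compound 3 and a 1.2-fold higher number (0.08 log units; within the scatter) from compound 2 to compound 4, 1.0-fold (0.02 log units) apart, within the scatter of two such steps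

Within these four compounds the two changes behave as independent of each other, but this rests on two pairs in a single cell assay and does not show that the chloro step would hold on any other core in the series, nor does it explain the step.

Still open, from the compounds shown here alone, is whether a fluoro, bromo or methoxy group at the same place would give a step of similar size to chloro. Also open, going by these compounds, is whether a longer chain, or an amine or carboxylic acid on the chain, would leave the chloro step intact.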